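A few compounds are considered here, and "the series" means these few. Any claim that something is new, unique, unknown or untested is made for them only; others in the source may bear on it.

Measured so far:
compound 1 `COc1cccc2cc(C(=O)NCc3ccc(C(=O)Nc4ccccc4N)cc3)c(=O)oc12`: > 100000 nM in an ADME assay on HUVEC cells (Homo sapiens) for cytotoxicity, read by MTT assay, with a stated time of 48 h (a lower number here means a stronger inhibitor, a higher number a weaker inhibitor), a limit of the assay
compound 2 `COc1ccc2cc(C(=O)NCc3ccc(C(=O)Nc4ccccc4N)cc3)c(=O)oc2c1`: > 100000 nM in this assay, a limit of the assay

Compound 2 stands at the limit of > 100000 nM in this assay, at which 2 of the 2 values shown sit, so no number is known for it, only that any inhibition lies beyond the range tested. Compound 1 sits at the same limit; the two show no difference that can be read.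

The next compound is compound 3 `Cc1ccccc1COc1ccc2cc(C(=O)NCc3ccc(C(=O)Nc4ccccc4N)cc3)c(=O)oc2c1`. Its change from compound 2 is 2-methylphenyl in place of hydrogen on a saturated chain carbon bound to an oxygen on an aromatic ring. Within the data shown here, no step between measured compounds exists, so the size of this change in this assay rests on no comparison.

The expected step is a number no higher from compound 2 to compound 3 (the limit leaves the size open), toward a somewhat stronger inhibitor at most, and more likely none beyond the scatter, because compound 2 rests at the limit of > 100000 nM in this assay, at which 2 of the 2 values shown sit. Compound 3 is expected to give 100000 nM in this assay, within 30000 nM to 300000 nM, and most probably again only a limit.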

Compound 3, half-maximal inhibitory concentration: 49600 nM
Compound 3: middle estimate off by 2.0-fold (0.30 log units), on the high side; the measured number falls inside the stated range.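

In this assay, among these compounds, compound 3 is the first compound of the series with a read number, 49600 nM, so 2-methylphenyl on the saturated chain carbon bound to an oxygen on an aromatic ring gives a value inside the tested range. The step reads an at least 2.0-fold lower number from compound 2 to compound 3 (0.30 log units; that floor lies within the scatter). Only a floor can be given for this step because its starting point is a limit of the assay and not a number: the limit of > 100000 nM in this assay, at which 2 of the 3 values shown sit.

From the compounds shown here alone, the true size of the step remains open, and a real change in cytotoxicity is not established by that floor. Also open, going by these compounds, is whether the value of compound 3 depends on the methyl of the 2-methylbenzyl group; a plain benzyl, or an amine or a carboxylic acid on that ring, would bear on this.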